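The source may report more compounds than this note shows. Statements on the series, on what has been measured and on what is new or still open speak of the compounds shown alone.

Of the compounds shown here, three built on one shared core have been measured in a functional assay on PC-3 cells (Homo sapiens) for antiproliferative activity, read by MTT assay (on this read-out higher numbers stand for weaker inhibition and lower numbers for stronger inhibition), each differing only in the ring attached to a carbon with a double bond to nitrogen. Compound 1 `Cn1c(=O)c(=O)n(C2CCCC2)c2nc(N/N=C/c3ccc(O)cc3)ncc21`, with 4-hydroxyphenyl there, reaches only > 100000 nM in this assay, which is a limit and not a number. Compound 2 `Cc1cccc(/C=N/Nc2ncc3c(n2)n(C2CCCC2)c(=O)c(=O)n3C)c1` gives 53600 nM in this assay. Compound 3 `Cn1c(=O)c(=O)n(C2CCCC2)c2nc(N/N=C/c3ccc(F)cc3Cl)ncc21` gives 15200 nM, the lowest of the two numbers in hand. The steps of an at least 1.8-fold lower number from compound 1 to compound 2 (0.27 log units; that floor lies within the scatter), an at least 6.5-fold lower number from compound 1 to compound 3 (0.81 log units; beyond the scatter) and a 3.5-fold lower number from compound 2 to compound 3 (0.55 log units; beyond the scatter) all swap this ring, and only the move to 2-chloro-4-fluorophenyl clears the scatter. Compound 4 `COc1ccc(/C=N/Nc2ncc3c(n2)n(C2CCCC2)c(=O)c(=O)n3C)c(OC)c1` makes the change (2,4-dimethoxyphenyl in place of 2-chloro-4-fluorophenyl on a carbon with a double bond to nitrogen). Leaving the ring that gave the step of a 3.5-fold lower number from compound 2 to compound 3 (0.55 log units; beyond the scatter) is expected to raise the number, a 2.6-fold higher number from compound 3 to compound 4 (0.42 log units; beyond the scatter). Compound 4 is therefore estimated at 40000 nM, between 12000 nM and 130000 nM.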

Compound 4, half-maximal inhibitory concentration: > 100000 nM
Compound 4 ended at the assay's limit (the forecaster's own chance of this, stated with the estimate: 30%); middle value at least 2.5-fold (0.39 log units) away from the limit.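

In this assay, replacing 2-chloro-4-fluorophenyl with 2,4-dimethoxyphenyl gives an at least 6.5-fold higher number from compound 3 to compound 4 (0.81 log units; beyond the scatter), so the matching placement of two groups on the ring does not preserve activity, and the groups themselves matter. Against 3-methylphenyl the change gives an at least 1.8-fold higher number from compound 2 to compound 4 (0.27 log units; that floor lies within the scatter), so no order can be claimed between those two rings. Compound 1 and compound 4 both end at a limit and not a number, so the step between them cannot be read: the limit of > 100000 nM in this assay, at which 2 of the 4 values shown sit.

Going by these compounds, it remains open whether the chlorine, the fluorine or both account for the lower number of compound 3. On these data alone, how a ring bearing an amine or a carboxylic acid would read is also open.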